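The compounds below may be only part of what the source reports. "The series", "measured", "known", "first", "only" and "open" are said of these compounds alone.

Compound 2 `COc1cc(/C=C/c2nc3cc(Cl)cnc3n(CC(=O)O)c2=O)ccc1O` has been measured in a functional assay, read by spectrophotometry, with a stated time of 30 min, tested at 100 uM (a higher number here means a stronger effect of the compound at the concentration tested, a lower number a weaker effect), where compound 2 gives 94.9%. Among the three compounds measured, compound 2 stands second highest. Compound 1 `O=C(O)Cn1c(=O)c(/C=C/c2ccc(O)c(O)c2)nc2cc(Cl)cnc21` is its nearest neighbour; in this assay compound 1 gives 97.1%. For the measured compounds named here, the single change between these two, methyl in place of hydrogen on an oxygen on an aromatic ring, gives a number 2.2 percentage points lower from compound 1 to compound 2 (within the scatter), a step within the scatter. Furthest away is compound 3 `COc1cc(CCc2nc3cccnc3n(CC(=O)O)c2=O)ccc1O`, which in this assay gives 40.1%; compound 3 differs from compound 2 in more than one place, so only its two values are noted, without a single step drawn between them.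

Compound 4 `COc1cc(/C=C/c2nc3cc(Br)cnc3n(CC(=O)O)c2=O)ccc1O` has not yet been measured. It differs from compound 2 as follows: bromo in place of chloro on an aromatic carbon. Going by the values given here, none of the measured steps alters this group, so no measured step bears directly on the change. Among the compounds with values here, the only single-place step known, from compound 1 to compound 2, concerns a different part of the molecule and lies within the scatter. The author therefore expects no step beyond the scatter in this assay; the expected step is a number 1.9 percentage points lower from compound 2 to compound 4 (within the scatter). Compound 4 is estimated to give 93% in this assay, within a range from 80% to 100%.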

Compound 4, a percentage reported as activity, at one concentration (the size of the read-out at that concentration, not a potency): 90.1%
Compound 4: the middle estimate sits 2.9 percentage points above what was measured; low and high end bracket the measured number.
By their numbers in this assay, from the lowest: compound 3; then compounds 4, 2 and 1 (each within the scatter of the next).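

For the compounds shown here, the step of a number 4.8 percentage points lower from compound 2 to compound 4 (within the scatter) in this assay is the first measured step to touch this position, a carbon of the six-membered aromatic ring with 1 nitrogen, two atoms from the ring nitrogen. The earlier single-place step concerned the oxygen on the other aromatic ring, so it said nothing about the halogen; now bromo in place of chloro shows that this read-out does not separate the two halogens at this position. No measurement among the data accounts for that result or ties it to any property of either group.

What the compounds shown leave open is whether this position matters at all, since chloro and bromo are the only groups compared there, and compound 3, which has neither, also differs from compound 2 in other places, so its value cannot be credited to the halogen alone. Whether a smaller or quite different group at this carbon, such as fluoro, a nitrile or an amine, would keep the read-out in the same range remains an open question.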